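Ring methyl removed from compound 1: expectation for compound 4

The source may report more compounds than this note shows. Statements on the series, on what has been measured and on what is new or still open speak of the compounds shown alone.

Values in a functional assay on MCF7 cells (Homo sapiens) for antiproliferative activity, read by MTT assay; a higher number here means a weaker inhibitor, a lower number a stronger inhibitor:
compound 1 `CCCC/C=C\CCCCCCCCCc1cc(=O)c2c(O)cc(O)c(C)c2o1` — 17500 nM
compound 2 `CCCCC/C=C\C/C=C\CCCCCCCc1cc(=O)c2c(O)cc(O)c(C)c2o1` — 17500 nM
compound 3 `CCCC/C=C\CCCCCCCCCc1cc(=O)c2c(O)c(C)c(O)c(C)c2o1` — a limit of the assay, not a number: > 67200 nM

Among the measured compounds shown here, compound 1 stands level with compound 2, no change at the digits printed from compound 1 to compound 2 (within the scatter) lying within the scatter; the only other value shown is the limit of compound 3. Compound 4 `CCCC/C=C\CCCCCCCCCc1cc(=O)c2c(O)cc(O)cc2o1` differs from compound 1 by hydrogen in place of methyl on an aromatic carbon. For the measured compounds named here, the one measured step that bears on this change is an at least 3.8-fold higher number from compound 1 to compound 3 (0.58 log units; beyond the scatter), a step of at least modest size whose endpoint sits at the limit of > 67200 nM in this assay, at which 1 of the 3 values shown sits. That step adds a methyl on an aromatic carbon of the shared core and weakens; compound 4 instead loses a methyl on an aromatic carbon, so the expected movement is in the opposite direction, modest at most, or none beyond the scatter. Compound 4 is therefore estimated at 12000 nM, with a range of 5000 nM to 35000 nM. The expected step is a 1.5-fold lower number from compound 1 to compound 4 (0.16 log units; within the scatter).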

Compound 4, half-maximal inhibitory concentration: 17500 nM
Beside the measured number, compound 4's estimate is 1.5-fold (0.16 log units) below it; measured number inside the range.
By their numbers in this assay, from the lowest: compounds 1, 2 and 4 (each within the scatter of the next). At a limit, above all of these: compound 3.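

In this assay, replacing methyl with hydrogen on this aromatic carbon gives no change at the digits printed from compound 1 to compound 4 (within the scatter), so this methyl can be lost without a change beyond the scatter. The earlier step, an at least 3.8-fold higher number from compound 1 to compound 3 (0.58 log units; beyond the scatter), adds a methyl on a different aromatic carbon of the shared core, so the two places do not respond alike. Compound 3 stands at a limit of the assay: the limit of > 67200 nM in this assay, at which 1 of the 4 values shown sits.

From the compounds shown here alone, whether an ethyl, a methoxy or an amine at the carbon changed in compound 4 would also leave the read-out in place remains open. Also open, going by these compounds, is whether the hydrogen of compound 4 is tolerated with a shorter chain.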